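A Nitrophenoxy Hydrazone Built on an Unreadable Baseline

A few compounds are considered here, and "the series" means these few. Any claim that something is new, unique, unknown or untested is made for them only; others in the source may bear on it.

Compound 2 `CCCCC(=O)N/N=C/c1c(C(=O)OCC)[nH]c2cc(Cl)ccc12` stands at the edge of an assay for inhibition of Polyunsaturated fatty acid lipoxygenase ALOX15 (Homo sapiens), with a stated time of 8 min; a higher number here means a weaker inhibitor, a lower number a stronger inhibitor; in this assay compound 2 gives > 10000 nM, which is a limit, not a number. Compound 1 `CCOC(=O)c1[nH]c2cc(Cl)ccc2c1/C=N/NC(=O)CCc1ccccc1` gives > 10000 nM in this assay, also a limit. Among the measured compounds shown here, the one measured step, a step that the two limits leave unreadable from compound 1 to compound 2, cannot be sized because both values sit at the limit of > 10000 nM in this assay, at which 2 of the 2 values shown sit. Compound 3 `CCOC(=O)c1[nH]c2cc(Cl)ccc2c1/C=N/NC(=O)COc1ccc([N+](=O)[O-])cc1` differs from compound 2 by 4-nitrophenoxy in place of propyl on a saturated chain carbon bound to a carbonyl carbon. No readable step bears on this change, so for compound 3 no shift beyond the scatter is expected, its step that the limit leaves unreadable from compound 2 to compound 3 being estimated from a limit alone. Compound 3 is expected near 15000 nM, within 4000 nM to 60000 nM.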

Compound 3, half-maximal inhibitory concentration: > 10000 nM
Compound 3 gave a limit, no number; the forecaster's own chance of this, stated with the estimate: 75%; the middle value is on the limit's open side.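

In this assay, among the compounds shown here, compound 3 gives only a limit, so no step linking compound 1, compound 2 and compound 3 can be read: the limit of > 10000 nM in this assay, at which 3 of the 3 values shown sit. The compounds shown leave open whether any of these chain groups gives a readable inhibition value.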